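Replacing the carbamoylphenyl arm of compound 2 with tetrazole

The source may report more compounds than this note shows. Statements on the series, on what has been measured and on what is new or still open speak of the compounds shown alone.

Compound 1 `O=C(CCCCCCc1ccccc1)c1ncc(-c2cccc(O)c2)o1` gives 50 nM in an assay (Rattus norvegicus) for inhibition of Fatty-acid amide hydrolase 1 (Homo sapiens); a higher number here means a weaker inhibitor, a lower number a stronger inhibitor.
Compound 2 `NC(=O)c1ccc(-c2cnc(C(=O)CCCCCCc3ccccc3)o2)cc1` gives 10 nM in this assay.
Compound 3 `O=C(CCCCCCc1ccccc1)c1ncc(-c2ccc(C(=O)C(F)(F)F)cc2)o1` gives 65 nM in this assay.

Compound 2 holds the lowest number of the three, and both of its neighbours lie beyond the scatter: the step of a 5.0-fold lower number from compound 1 to compound 2 (0.70 log units; beyond the scatter) and the step of a 6.5-fold higher number from compound 2 to compound 3 (0.81 log units; beyond the scatter) show that the group on the shared core matters. Compound 4 `O=C(CCCCCCc1ccccc1)c1ncc(-c2nnn[nH]2)o1` keeps the core and the long chain but changes that group: 1H-tetrazol-5-yl in place of 4-carbamoylphenyl on an aromatic carbon. Within the data shown here, no measured step removes the six-membered ring entirely, so the two known steps only set a scale: swapping one group for another on that ring already moved the number well beyond the scatter in each direction. A more drastic change is therefore expected to move it further, and away from the best value, since the amide-bearing ring is gone. The step of a 20-fold higher number from compound 2 to compound 4 (1.30 log units; beyond the scatter) is the expected outcome. Compound 4 is estimated at 200 nM, within 40 nM to 1000 nM.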

Compound 4, inhibition constant: 63 nM
Compound 4: middle estimate off by 3.2-fold (0.50 log units), on the high side; the measured number falls inside the stated range.
By their numbers in this assay, from the lowest: compound 2; then compounds 1, 4 and 3 (each within the scatter of the next).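

This position on the shared core does not need a six-membered ring to stay in the same range of numbers. In this assay, 1H-tetrazol-5-yl, with fewer heavy atoms than either ring it is compared with, shows a 1.3-fold higher number from compound 1 to compound 4 (0.10 log units; within the scatter), so it cannot be told apart from 3-hydroxyphenyl. Set against 4-carbamoylphenyl, the same group shows a 6.3-fold higher number from compound 2 to compound 4 (0.80 log units; beyond the scatter), which ties the low number of compound 2 to that particular group and not to just any aromatic ring here. Nothing shown gives a reason for these numbers.

Still open, from the compounds shown here alone, is whether a carboxylic acid or a plain amide at this position could reach the number of compound 2 without the ring. Going by these compounds, it is also open whether an unsubstituted phenyl group would sit closer to compound 1 or to compound 2.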